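Isobutoxy for Azepanyl on a Trifluoromethyl Benzylamide

The source may report more compounds than this note shows. Statements on the series, on what has been measured and on what is new or still open speak of the compounds shown alone.

Compound 1 `CC(C(=O)NCc1ccc(C(F)(F)F)cc1N1CCCCCC1)c1ccc(NS(C)(=O)=O)c(F)c1` gives 1.6 nM in an assay on CHO cells for antagonist activity at transient receptor potential cation channel subfamily V member 1 (Homo sapiens), read by FLIPR; on this read-out higher numbers stand for weaker inhibition and lower numbers for stronger inhibition. Compound 3 `COc1ccc(N2CCN(c3cc(C(F)(F)F)ccc3CNC(=O)C(C)c3ccc(NS(C)(=O)=O)c(F)c3)CC2)cc1` gives 1.6 nM, the same at the digits shown, so the two share the highest of the three numbers. Compound 2 `CC(C(=O)NCc1ccc(C(F)(F)F)cc1N1CCC(c2ccc(F)cc2)CC1)c1ccc(NS(C)(=O)=O)c(F)c1` gives 0.9 nM, a somewhat lower number that still lies within the scatter of compound 1. Compound 4 `CC(C)COc1cc(C(F)(F)F)ccc1CNC(=O)C(C)c1ccc(NS(C)(=O)=O)c(F)c1` awaits measurement; it differs from compound 1 in one place: isobutoxy in place of azepan-1-yl on an aromatic carbon. For the measured compounds named here, no measured pair shows a change of this kind, so only an expectation can be offered: a modest rise in the number is expected, a 2.5-fold higher number from compound 1 to compound 4 (0.40 log units; beyond the scatter), likely near the edge of the scatter. Compound 4 is estimated at 4 nM, with a range from 1 nM to 15 nM.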

Compound 4, inhibition constant: 0.8 nM
Estimate against measurement, compound 4: 5.0-fold (0.70 log units) above; the whole stated range lies above it.
By their numbers in this assay, from the lowest: compounds 4, 2, 1 and 3 (each within the scatter of the next).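

At this aromatic carbon, isobutoxy in place of azepan-1-yl gives a 2.0-fold lower number from compound 1 to compound 4 (0.30 log units; within the scatter) in this assay. Compound 1, compound 2 and compound 3 all carry a ring joined through nitrogen here, whereas compound 4 shows that an open chain joined through oxygen also fits this read-out, with no change beyond the scatter. Nothing measured here accounts for this result.

For the compounds shown here, the single step changes the ring and the linking atom together, so their separate contributions cannot be told apart. From the compounds shown here alone, how a shorter ethoxy group or an open-chain diethylamino group would read at this carbon remains open.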